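Adding a methoxy group to compound 1

This account rests on a few compounds, and the source may have more. Where it says the series, first, only, none or still open, it means among the compounds named here.

Measured so far:
compound 1 `C/C(=C\c1ccccc1)C(=O)/C=C/c1ccccc1`: 34500 nM
compound 2 `C/C(=C\c1ccccc1)C(=O)/C=C/c1ccc(N(C)C)cc1`: 20200 nM

Both numbers come from an ADME assay on J774.A1 cells (Mus musculus) for cytotoxicity, read by MTT assay, with a stated time of 48 h; on this read-out lower numbers stand for higher toxicity in this test and higher numbers for lower toxicity in this test. For the measured compounds named here, compound 1 lies within the usual scatter of compound 2, the only other measured compound. Compound 3 `COc1ccc(/C=C(\C)C(=O)/C=C/c2ccccc2)cc1` has methoxy in place of hydrogen on an aromatic carbon of the core of compound 1, para to a large group: methoxy in place of hydrogen on an aromatic carbon. Going by the values given here, the one measured step bearing on this is a 1.7-fold lower number from compound 1 to compound 2 (0.23 log units; within the scatter), which puts dimethylamino in place of hydrogen on an aromatic carbon. On that single step, no change beyond the scatter is expected in this assay. The estimated step is a 1.2-fold lower number from compound 1 to compound 3 (0.09 log units; within the scatter). The expected value for compound 3 is 28000 nM, with an estimated range of 13000 nM to 58000 nM.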

Compound 3, half-maximal cytotoxic concentration: 54000 nM
Beside the measured number, compound 3's estimate is 1.9-fold (0.29 log units) below it; the range from low to high includes it.
By their numbers in this assay, from the lowest: compounds 2, 1 and 3 (each within the scatter of the next, the first and the last beyond it).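

Putting methoxy in place of hydrogen on this aromatic carbon, para to a large group, gives a 1.6-fold higher number from compound 1 to compound 3 (0.19 log units; within the scatter) in this assay and so shows no change beyond the scatter for this swap at this position. This first reading at this position gives no sign that the methoxy group changes the cytotoxicity number. No measurement available here explains the result.

As far as these compounds go, whether a carboxylic acid or a longer chain at this same carbon would move the number beyond the scatter stays open. So does whether methoxy would behave alike elsewhere on the shared core.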